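Methoxy in place of hydroxy on the chlorophenyl ring

A few compounds are considered here, and "the series" means these few. Any claim that something is new, unique, unknown or untested is made for them only; others in the source may bear on it.

Compound 3 `O=C(Nc1cccc(-n2cc(-c3ccncc3)c(-c3cc(O)cc(Cl)c3)n2)c1)Nc1ccc(Cl)c(Cl)c1` gives 16.2% in a functional assay on SF-268 cells (Homo sapiens) for inhibition, read by sulforhodamine B assay, with a stated time of 48 h, tested at 10 uM (on this read-out lower numbers stand for a stronger effect and higher numbers for a weaker effect at the one concentration tested), the lowest of the three numbers to hand. Compound 1 `COc1cc(Cl)cc(-c2nn(-c3cccc(NC(=O)Nc4cccc(C(F)(F)F)c4)c3)cc2-c2ccncc2)c1` gives 27.9% and compound 2 `COc1cc(Cl)cc(-c2nn(-c3cccc(NC(=O)c4cccc(C(F)(F)F)c4)c3)cc2-c2ccncc2)c1` gives 77.3%; both stand higher than compound 3, beyond the scatter. For the measured compounds named here, the one step measured in a single place, a number 49.4 percentage points higher from compound 1 to compound 2 (beyond the scatter), concerns the carbonyl substituent and says nothing about the oxygen on the chlorophenyl ring.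

Compound 4 `COc1cc(Cl)cc(-c2nn(-c3cccc(NC(=O)Nc4ccc(Cl)c(Cl)c4)c3)cc2-c2ccncc2)c1` differs from compound 3 only there: methyl in place of hydrogen on an oxygen on an aromatic ring. Compound 1 also carries the methoxy, but it differs from compound 3 in the urea aryl group as well, so its number cannot be read as a step for the hydroxy to methoxy change alone. Going by the values given here, no measured step bears on this change; the expectation is therefore a step of no particular direction, with the estimate set to lie near compound 3 and well within its scatter, a number 4.8 percentage points higher from compound 3 to compound 4 (within the scatter). For compound 4 the expected value in this assay is 21%, with a range from 8% to 40%.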

Compound 4, a percentage reported as activity, at one concentration (the size of the read-out at that concentration, not a potency): 25.3%
Compound 4: middle estimate off by 4.3 percentage points, on the low side, within the range that was stated.
By their numbers in this assay, from the lowest: compounds 3, 4 and 1 (each within the scatter of the next, the first and the last beyond it); then compound 2.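

Within this assay the change from hydroxy to methoxy gives a number 9.1 percentage points higher from compound 3 to compound 4 (within the scatter) and is the first reading of this oxygen in a single place: methyl in place of hydrogen there leaves the number within the usual spread. With the methoxy held, the urea aryl groups give a number 2.6 percentage points lower from compound 1 to compound 4 (within the scatter) and so are not separated by this read-out. For the compounds shown here, the amide compound 2 stands apart from this urea as well, with a number 52 percentage points lower from compound 2 to compound 4 (beyond the scatter) adding a second large step to the one seen with compound 1.

Open, on these data alone, is how an ethoxy group or an amine at this place on the 3-chloro-5-methoxyphenyl ring would read, and whether the gap between amide and urea also holds with the hydroxy. No measurement at hand accounts for any of these steps.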